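Swapping ethoxy for 4-chlorophenyl on compound 1

The compounds below may be only part of what the source reports. "The series", "measured", "known", "first", "only" and "open" are said of these compounds alone.

- compound 1 `CCOc1ncnc2c1ncn2C[C@@H]1C[C@H](CO)c2ccccc21` gives 24 ug/mL
- compound 2 `Cn1ncc2c1[C@H](Cn1cnc3c(Cl)ncnc31)C[C@@H]2CO[Si](c1ccccc1)(c1ccccc1)C(C)(C)C` gives 3.2 ug/mL

In a functional assay on MOLT-4 cells (Homo sapiens) (on this read-out higher numbers stand for weaker inhibition and lower numbers for stronger inhibition), compound 1 gives 24 ug/mL as the higher of the two numbers, so it is the weaker inhibitor of the pair. Compound 3 `OC[C@H]1C[C@@H](Cn2cnc3c(-c4ccc(Cl)cc4)ncnc32)c2ccccc21` is compound 1 with 4-chlorophenyl in place of ethoxy on an aromatic carbon and nothing else changed. For the measured compounds named here, no measured pair isolates this swap. Going by the values given here, the only guide is compound 2 at 3.2 ug/mL as a sign that lower numbers occur in this small set. A moderate step towards stronger inhibition is therefore expected in this assay and the expected size is a 2.7-fold lower number from compound 1 to compound 3 (0.43 log units; beyond the scatter) with wide uncertainty. For compound 3 the estimate is 9 ug/mL and the expected range is 2.5 ug/mL to 30 ug/mL.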

Compound 3, half-maximal inhibitory concentration: 0.63 ug/mL
Estimate against measurement, compound 3: 14-fold (1.15 log units) above; the measured number lies below the stated range.
By their numbers in this assay, from the lowest: compound 3; then compound 2; then compound 1.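

Swapping ethoxy for 4-chlorophenyl on the aromatic carbon next to the ring nitrogen gives, in this assay, a 38-fold lower number from compound 1 to compound 3 (1.58 log units; beyond the scatter). For the compounds shown here, this is the first single-place comparison in the set, and it shows that this carbon can carry a six-membered aromatic ring and that the change strongly affects the read-out. Nothing available explains the size of this step.

Going by these compounds, it remains open whether the ring alone or its chlorine matters, which plain phenyl at this carbon would separate. An amine or a longer alkoxy chain there also remains untested in the compounds shown.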